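Methoxycarbonyl to carboxy at the limit of cytotoxicity testing

The source may report more compounds than this note shows. Statements on the series, on what has been measured and on what is new or still open speak of the compounds shown alone.

Measured in a functional assay on PC-3 cells (Homo sapiens) for cytotoxicity (on this read-out lower numbers stand for stronger inhibition and higher numbers for weaker inhibition), so far:
- Compound 1 (`COc1c(C)c(/C=C/C(=O)O)oc(=O)c1CO`) gives > 50000 nM as a limit
- Compound 2 (`COC(=O)/C=C/c1oc(=O)c(CO)c(OC)c1CO`) gives > 50000 nM as a limit

Compound 2 stands at the limit of > 50000 nM in this assay, at which 2 of the 2 values shown sit, and this is a limit, not a number. Compound 3 (`COc1c(CO)c(/C=C/C(=O)O)oc(=O)c1CO`) differs from it by hydrogen in place of methyl on an oxygen next to a carbonyl group with hydrogen in place of methyl on an oxygen next to a carbonyl group, turning methoxycarbonyl into carboxy. Among the measured compounds shown here, no measured pair shows this change. With compound 1 at > 50000 nM as a limit, no step beyond the scatter is expected in this assay for this change. The expected step is a number no higher from compound 2 to compound 3 (the limit leaves the size open) in size. For compound 3 the estimated value is 50000 nM (expected range 25000 nM to 100000 nM).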

Compound 3, half-maximal inhibitory concentration: > 50000 nM
Compound 3: a limit, no number (the forecaster's own chance of this, stated with the estimate: 85%); the middle value lies on the limit itself.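

No step can be read between compound 1, compound 2 and compound 3, since each value is a limit and not a number: the limit of > 50000 nM in this assay, at which 3 of the 3 values shown sit. The compounds shown leave open whether methoxycarbonyl and carboxy differ at all in this assay.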